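This account rests on a few compounds, and the source may have more. Where it says the series, first, only, none or still open, it means among the compounds named here.

Measured compounds in an ADME assay on Akata cells (Homo sapiens) for cytotoxicity, with a stated time of 7 days; on this read-out higher numbers stand for lower toxicity in this test and lower numbers for higher toxicity in this test:

- compound 1, `CCCCCCCCOc1nc(N)nc2c1ncn2/C=C1/CC1(CO)CO`, gives > 20000 nM, which is a limit of the assay and not a number.
- compound 2, `CSc1nc(N)nc2c1ncn2/C=C1/CC1(CO)CO`, gives > 20000 nM, again a limit.
- compound 3, `CCCCCCOc1nc(N)nc2c1ncn2/C=C1/CC1(CO)CO`, gives > 20000 nM, again a limit.

Compound 3 therefore stands at the same place as the other two: none of the three gave a readable number. The three steps between them, a step that the two limits leave unreadable from compound 1 to compound 2, a step that the two limits leave unreadable from compound 1 to compound 3 and a step that the two limits leave unreadable from compound 2 to compound 3, are all unreadable because every value sits at the limit of > 20000 nM in this assay, at which 3 of the 3 values shown sit. Exchanging an octyloxy chain for a methylsulfanyl group, shortening the chain, or exchanging methylsulfanyl for hexyloxy left the toxicity beyond what this assay can see.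

Compound 4, `CC(C)Nc1nc(N)nc2c1ncn2/C=C1/CC1(CO)CO`, is not yet measured. It differs from compound 3 in one place: isopropylamino in place of hexyloxy on an aromatic carbon.

Within the data shown here, the steps that bear on this change, a step that the two limits leave unreadable from compound 2 to compound 3 and a step that the two limits leave unreadable from compound 1 to compound 3, are both unreadable, so they show only that varied groups at this position all stayed beyond the limit in this assay. No shown step gives a reason to expect a readable number for compound 4. Compound 4 is therefore expected to give about 30000 nM, within 10000 nM to 80000 nM. For compound 4 the expected step is a step that the limit leaves unreadable from compound 3 to compound 4.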

Compound 4, half-maximal cytotoxic concentration: > 24000 nM
Compound 4 gave a limit, no number; the forecaster's own chance of this, stated with the estimate: 80%; the middle value does not contradict the limit.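

Compound 4, like compound 1, compound 2 and compound 3, gives only a limit in this assay, so no step between any of these compounds can be read. The compounds shown leave open how toxic each one actually is, and whether any group at this position would give a readable number in this assay.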